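The compounds below may be only part of what the source reports. "The series", "measured", "known", "first", "only" and "open" are said of these compounds alone.

Of the compounds shown here, two sharing one core have been measured in a functional assay on the whole organism (Hindlimb) for inhibition, with Mus musculus as the target, with a stated time of 0.5 h; a lower number here means that less compound is needed, a higher number that more compound is needed for the effect. Compound 1 `CC1(C)CC12NC(=O)N(NC(=O)c1ccccc1)C2=O` carries an unsubstituted phenyl on the carbonyl carbon; in this assay compound 1 gives 300 mg/kg. Compound 2 `CC1(C)CC12NC(=O)N(NC(=O)c1ccc(Cl)cc1)C2=O` carries a 4-chlorophenyl in its place, and in this assay compound 2 gives 100 mg/kg. Among the measured compounds shown here, the only step measured so far is a 3.0-fold lower number from compound 1 to compound 2 (0.48 log units; beyond the scatter), so compound 2 stands with the lowest number of the two, with compound 1 as its nearest neighbour at a higher value.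

Compound 3 `CC1(C)CC12NC(=O)N(NC(=O)c1ccccc1Cl)C2=O` is the third member. It differs from compound 2 as follows: 2-chlorophenyl in place of 4-chlorophenyl on a carbonyl carbon. The chlorine stays; only its position on the aromatic ring changes. For the measured compounds named here, no measured step covers such a shift of position; the one step available shows only that adding chlorine lowered the number, and it says nothing about where on the ring the chlorine is best placed. The expectation is therefore a small step, a 2.0-fold higher number from compound 2 to compound 3 (0.30 log units; within the scatter), quite possibly within the scatter. Compound 3 is estimated at 200 mg/kg, within a range from 100 mg/kg to 600 mg/kg.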

Compound 3, minimum effective dose: 300 mg/kg
Beside the measured number, compound 3's estimate is 1.5-fold (0.18 log units) below it; measured number inside the range.
By their numbers in this assay, from the lowest: compound 2; then compounds 1 and 3 (each within the scatter of the next).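

In this assay the place of the chlorine on the ring matters: 2-chlorophenyl in place of 4-chlorophenyl gives a 3.0-fold higher number from compound 2 to compound 3 (0.48 log units; beyond the scatter) and takes back the whole drop seen on adding chlorine to compound 1. Set against the unsubstituted phenyl, the 2-chlorophenyl shows no change at the digits printed from compound 1 to compound 3 (within the scatter) and so adding chlorine lowers the number in compound 2 but not in compound 3, which means that the lower number belongs to the 4-chlorophenyl and not to the presence of chlorine alone. Nothing available here explains this difference between the two chlorophenyl groups.

The compounds shown leave open whether another group on the phenyl ring, such as a fluorine, a methyl group or an amine, would behave like the chlorine of compound 2 or like the chlorine of compound 3. They also leave open whether the 4-chlorophenyl would keep its lower number if the shared core were changed, for example by a longer chain on it.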